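Fluorine for Chlorine on the Hydroxybenzamide Ring

The source may hold more compounds than are shown below. What is called first, only, known or untested is meant among the compounds shown, and "the series" means these compounds.

Compound 1 `O=C(Nc1cc(C(F)(F)F)cc(C(F)(F)F)c1)c1ccccc1O` gives in an assay on cells for antagonist activity at P2X purinoceptor 2 (Homo sapiens), read by fluorescence and calcium flux, with a stated time of 30 min (on this read-out higher numbers stand for weaker inhibition and lower numbers for stronger inhibition), a reading of > 10000 nM, which is a limit of the assay rather than a number.
Compound 2 `O=C(Nc1cc(C(F)(F)F)cc(C(F)(F)F)c1)c1cccc(Cl)c1O` gives in this assay a reading of > 10000 nM, likewise a limit.
Compound 3 `O=C(Nc1cc(C(F)(F)F)cc(C(F)(F)F)c1)c1ccc(Cl)cc1O` gives in this assay a reading of > 10000 nM, again a limit.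

All three measured compounds share the same core, an anilide of a hydroxybenzoic acid, and differ only in a chloro group on the hydroxyphenyl ring. Compound 3 therefore stands where everything measured so far stands: at the limit of > 10000 nM in this assay, at which 3 of the 3 values shown sit. With every reading a limit, none of the steps between them can be sized: a step that the two limits leave unreadable from compound 1 to compound 2, a step that the two limits leave unreadable from compound 1 to compound 3 and a step that the two limits leave unreadable from compound 2 to compound 3 are all unreadable.

Compound 4 `O=C(Nc1cc(C(F)(F)F)cc(C(F)(F)F)c1)c1cccc(F)c1O` differs from compound 3 by 3-fluoro-2-hydroxyphenyl in place of 4-chloro-2-hydroxyphenyl on a carbonyl carbon. For the measured compounds named here, the measured steps that bear on this change, being unreadable, give no direction and no size; the only guide is that three close relatives all fall at the limit. The step to compound 4 in this assay is therefore expected to show no movement beyond the scatter, with compound 4 most likely also returning a limit. Compound 4 is estimated at 20000 nM, within a range from 5000 nM to 100000 nM. That estimate implies a step that the limit leaves unreadable from compound 3 to compound 4, expected to stay within the scatter.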

Compound 4, half-maximal inhibitory concentration: > 10000 nM
Compound 4: no number, only a limit (the forecaster's own chance of this, stated with the estimate: 85%); the middle value lies beyond the limit too.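

Compound 4, like compound 1, compound 2 and compound 3, returns only a limit of the assay, so its steps to those three cannot be read: the limit of > 10000 nM in this assay, at which 4 of the 4 values shown sit. The compounds shown leave open how strongly any of them inhibits in this assay, and whether chloro or fluoro changes that at all.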